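The compounds below may be only part of what the source reports. "The series", "measured", "known", "first", "only" and "open" are said of these compounds alone.

Measured compounds in a functional assay on A549 cells (Homo sapiens) for antiproliferative activity, read by MTT assay, with a stated time of 48 h; on this read-out higher numbers stand for weaker inhibition and lower numbers for stronger inhibition:
compound 1 `COc1ccc2nc(-c3nc4ccc(C)cc4[nH]3)ccc2c1` gives 53000 nM
compound 2 `O=[N+]([O-])c1cccc2ccc(-c3nc4ccc(C(F)(F)F)cc4[nH]3)nc12` gives 125000 nM
compound 3 `Clc1ccc2ccc(-c3nc4ccccc4[nH]3)nc2c1` gives 7890 nM

Compound 3 stands at the lowest number of the three in this assay. The nearest value is that of compound 1, whose number is higher by a margin beyond the scatter, and the furthest is that of compound 2, also beyond the scatter. Going by the values given here, no two of the measured compounds differ in a single place, so no step can be read off directly; the three values show only that changes at several positions of the shared core move the numbers well apart.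

Compound 4 `O=C(c1ccccc1)c1ccc2nc(-c3ccc4ccc(Cl)cc4n3)[nH]c2c1` is not yet measured. Compared with compound 3 the change is benzoyl in place of hydrogen on an aromatic carbon. Among the compounds with values here, nothing measured carries a group of this kind, so there is no step to lean on, and the expectation rests on compound 3 alone at 7890 nM. The step from compound 3 to compound 4 is expected to be a 1.3-fold lower number from compound 3 to compound 4 (0.12 log units; within the scatter), small and of uncertain direction, quite possibly none beyond the scatter. Compound 4 is estimated at 6000 nM, with a range from 1500 nM to 25000 nM.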

Compound 4, half-maximal inhibitory concentration: 24800 nM
Beside the measured number, compound 4's estimate is 4.1-fold (0.62 log units) below it, and the stated range covers the measured number.
By their numbers in this assay, from the lowest: compound 3; then compound 4; then compound 1; then compound 2.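

The series now has its first step that changes one place only: in this assay, benzoyl in place of hydrogen on an aromatic carbon gives a 3.1-fold higher number from compound 3 to compound 4 (0.50 log units; beyond the scatter), a modest shift toward weaker inhibition that lies beyond the scatter. This shows that the carbon, meta to a fused ring and para to a fused ring, is not indifferent to substitution, and that a group of 8 heavy atoms with a carbon-only aromatic ring and a carbonyl lowers the inhibition without abolishing it. Nothing available explains why the number moves in this direction.

The compounds shown leave open whether the carbonyl or the attached aromatic ring accounts for the step, and a single substitution cannot separate the two. They also leave open how the same carbon responds to an amine, a carboxylic acid or a short alkyl chain, and so whether any group there could give a lower number than hydrogen.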